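The source may report more compounds than this note shows. Statements on the series, on what has been measured and on what is new or still open speak of the compounds shown alone.

In a functional assay on HepG2 cells (Homo sapiens) for inhibition, read by MTT assay, with a stated time of 72 h (on this read-out higher numbers stand for weaker inhibition and lower numbers for stronger inhibition), compound 1 (`Clc1ccc(-c2nnc(SCCCN3CCN(c4nc5ccccc5o4)CC3)o2)cc1`) gives 121000 nM and compound 2 (`O=[N+]([O-])c1ccc(-c2nnc(SCCCN3CCN(c4nc5ccccc5s4)CC3)o2)cc1`) gives 93300 nM as its value, so the two lie within the scatter of each other. Compound 3 (`Clc1ccc(-c2nnc(SCCCN3CCN(c4nc5ccccc5s4)CC3)o2)cc1`) has chloro in place of nitro on an aromatic carbon relative to compound 2 (chloro in place of nitro on an aromatic carbon). Within the data shown here, no measured step covers this change. Compound 1 also carries chloro and stands at 121000 nM in the same range, so no shift beyond the scatter is expected in this assay for this change. The expected size is a 1.1-fold higher number from compound 2 to compound 3 (0.03 log units; within the scatter) and no more. Compound 3 is estimated at 100000 nM with an expected range of 50000 nM to 190000 nM for the measurement.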

Compound 3, half-maximal inhibitory concentration: 87700 nM
Compound 3: the middle estimate sits 1.1-fold (0.06 log units) above what was measured; measured number inside the range.
By their numbers in this assay, from the lowest: compounds 3, 2 and 1 (each within the scatter of the next).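

In this assay, the change from 4-nitrophenyl to 4-chlorophenyl gives a 1.1-fold lower number from compound 2 to compound 3 (0.03 log units; within the scatter), so chloro and nitro on this aromatic carbon, para to a large group, are not separated. With chloro in place, 1,3-benzothiazol-2-yl instead of 1,3-benzoxazol-2-yl on the amine nitrogen in a ring gives a 1.4-fold lower number from compound 1 to compound 3 (0.14 log units; within the scatter), which also shows no separation. No measurement on hand bears on the reason for either result.

From the compounds shown here alone, an amine or a carboxylic acid in place of chloro on this aromatic carbon remains open. So does a longer chain in the shared core.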